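The compounds below may be only part of what the source reports. "The series", "measured", "known", "first", "only" and "open" are said of these compounds alone.

Measured compounds:
compound 1, `CCC1C(=O)N(C)c2cnc(Nc3ccc(S(=O)(=O)NCC(C)C)cc3)nc2N1c1ccn(C)n1`: 311 nM
compound 2, `CC[C@@H]1C(=O)N(C)c2cnc(-n3ccc4ccccc43)nc2N1C1CCCC1`: 355 nM
compound 3, `CC[C@@H]1C(=O)N(C)c2cnc(Nc3ccc(S(=O)(=O)NC4CCCC4)cc3)nc2N1C1CCCC1`: 23.9 nM

In an assay for inhibition of serine/threonine-protein kinase PLK2 (Homo sapiens), read by FRET and Z'-LYTE, with a stated time of 1 h (on this read-out lower numbers stand for stronger inhibition and higher numbers for weaker inhibition), compound 2 gives the highest of the three numbers. Its nearest neighbour is compound 1, whose value lies within the scatter of that of compound 2, so the two cannot be put in order. Compound 3 stands far lower, beyond the scatter, and is the only one of the three with a number clearly apart from compound 2.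

Compound 4, `CC[C@@H]1C(=O)N(C)c2cnc(-n3ccc4cc(C(=O)NCC(C)C)ccc43)nc2N1C1CCCC1`, differs from compound 2 in a single place: isobutylcarbamoyl in place of hydrogen on an aromatic carbon. Within the data shown here, no measured pair shows this kind of change, so the size of the step can only be guessed. The group enters on the part of compound 2 that compound 3 lacks, and compound 3 owes its lower number to a different substituent altogether, so nothing measured speaks directly for or against the change. An added group of this kind is expected to move the number somewhat downward, but the step from compound 2 to compound 4 is expected to be only a 2.4-fold lower number from compound 2 to compound 4 (0.37 log units; beyond the scatter), possibly within the scatter. Compound 4 is therefore estimated at 150 nM, with a range from 40 nM to 600 nM.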

Compound 4, half-maximal inhibitory concentration: 18.6 nM
Beside the measured number, compound 4's estimate is 8.1-fold (0.91 log units) above it; the measured number lies below the stated range.
By their numbers in this assay, from the lowest: compounds 4 and 3 (each within the scatter of the next); then compounds 1 and 2 (each within the scatter of the next).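

In this assay, among these compounds, isobutylcarbamoyl in place of hydrogen on this aromatic carbon gives a 19-fold lower number from compound 2 to compound 4 (1.28 log units; beyond the scatter), the first change in a single place whose size can be read. Among the compounds shown here, it shows that this carbon of the six-membered aromatic ring of carbon only, which none of the earlier compounds had probed, can carry a group of this size and that the change is large. Nothing measured here accounts for the size of this step.

Still open, on these data alone, is whether the carbonyl, the amide hydrogen or the isobutyl chain accounts for the step, which a carboxylic acid, a primary carboxamide or a methylamide on the same carbon would help to separate. Also open, as far as these compounds go, is whether isobutylcarbamoyl would give a similar step on the other carbons of that ring.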